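The source may hold more compounds than are shown below. What is called first, only, known or untested is meant among the compounds shown, and "the series" means these compounds.

- Compound 1 `CCCCCCCCCCCCn1cc(COC[C@@H]2OC[C@H](N)[C@H]2O)nn1` gives 2620 nM in a functional assay on MCF7 cells (Homo sapiens) for antiproliferative activity, read by MTT assay, with a stated time of 48 h; a lower number here means a stronger inhibitor, a higher number a weaker inhibitor
- Compound 2 `CCCCCCCCCCCCCCn1cc(COC[C@@H]2OC[C@H](N)[C@H]2O)nn1` gives 2450 nM in this assay

Of these two measured compounds, compound 2 lies within the scatter of compound 1, so neither stands apart. Compound 3 `CCCCCCCCCCCCCCCCCCn1cc(COC[C@@H]2OC[C@H](N)[C@H]2O)nn1` differs from compound 2 by butyl in place of hydrogen on a saturated chain carbon, ten or more bonds along the chain from an aromatic nitrogen, with butyl in place of hydrogen on a saturated chain carbon, ten or more bonds along the chain from an aromatic nitrogen. Among the measured compounds shown here, only one measured step bears on this change: a 1.1-fold lower number from compound 1 to compound 2 (0.03 log units; within the scatter), which came with ethyl in place of hydrogen on such a carbon. The butyl change is larger, and no measurement shows how a chain this long behaves. A step beyond the scatter in this assay is therefore not expected, and no direction is favoured. The expected change is a 1.1-fold higher number from compound 2 to compound 3 (0.03 log units; within the scatter) and remains uncertain. For compound 3 the estimated value is 2600 nM, within an expected range of 1200 nM to 6000 nM.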

Compound 3, half-maximal inhibitory concentration: 1930 nM
For compound 3 the middle estimate is 1.3-fold (0.13 log units) above the measured one; the range from low to high includes it.
By their numbers in this assay, from the lowest: compounds 3, 2 and 1 (each within the scatter of the next).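

In this assay, butyl in place of hydrogen on a saturated chain carbon, ten or more bonds along the chain from an aromatic nitrogen, gives a 1.3-fold lower number from compound 2 to compound 3 (0.10 log units; within the scatter) and so stays within the scatter, as the smaller ethyl step had done. The widest pair shown, with hexyl in place of hydrogen at that same place, gives a 1.4-fold lower number from compound 1 to compound 3 (0.13 log units; within the scatter) and also stays within the scatter, so compounds 1, 2 and 3 cannot be told apart in this assay and the added chain length shows no effect beyond the scatter. No measurement given here accounts for this result. Still open, going by these compounds, is how a much shorter chain such as hexyl would read, or a chain carrying an amine or a carboxylic acid. On these data alone, it is also open whether a longer chain would stay within the scatter.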